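Replacing 4-methoxyphenyl with furan-2-yl: an expected small step

A few compounds are considered here, and "the series" means these few. Any claim that something is new, unique, unknown or untested is made for them only; others in the source may bear on it.

In a functional assay on MCF7 cells (Homo sapiens) for inhibition, read by CCK-8 assay, with a stated time of 48 h (on this read-out lower numbers stand for stronger inhibition of growth and higher numbers for weaker inhibition of growth), compound 3 `COc1ccc(CNc2nc(Nc3ccc(N4CCN(C)CC4)cn3)ncc2Cl)cc1` gives 17300 nM. Compound 2 `CN1CCN(c2ccc(Nc3ncc(Cl)c(NCc4ccc(F)cc4)n3)nc2)CC1` gives 19300 nM, and compound 1 `CN1CCN(c2ccc(Nc3ncc(Cl)c(NCc4ccc(C(F)(F)F)cc4)n3)nc2)CC1` gives 28400 nM. All three lie within the scatter of one another, so compound 3 does not stand apart from either neighbour.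

The next structure, compound 4 `CN1CCN(c2ccc(Nc3ncc(Cl)c(NCc4ccco4)n3)nc2)CC1`, differs from compound 3 as follows: furan-2-yl in place of 4-methoxyphenyl on a saturated chain carbon bound to a nitrogen on an aromatic ring. This places furan-2-yl in place of 4-methoxyphenyl on a saturated chain carbon bound to a nitrogen on an aromatic ring.

Among the measured compounds shown here, three measured steps bear on this only indirectly, as each exchanges one group on an aromatic carbon and none exchanges the ring: a 1.5-fold lower number from compound 1 to compound 2 (0.17 log units; within the scatter), a 1.6-fold lower number from compound 1 to compound 3 (0.22 log units; within the scatter) and a 1.1-fold lower number from compound 2 to compound 3 (0.05 log units; within the scatter). For the measured compounds named here, no measured pair shows the effect of a ring exchange, so the direction is uncertain, and no step beyond the scatter is expected. The expected change is a 1.3-fold higher number from compound 3 to compound 4 (0.10 log units; within the scatter). The estimated value for compound 4 is 22000 nM, with an expected range of 10000 nM to 50000 nM.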

Compound 4, concentration for 50% growth inhibition: 21300 nM
The estimate for compound 4 lay 1.0-fold (0.01 log units) above the measured number; low and high end bracket the measured number.
By their numbers in this assay, from the lowest: compounds 3, 2, 4 and 1 (each within the scatter of the next).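

In this assay, among the compounds shown here, the earlier steps changed only a group on an aromatic carbon, whereas here the whole ring on a saturated chain carbon bound to a nitrogen on an aromatic ring is exchanged, and a five-membered aromatic ring with 1 hetero atom replaces a six-membered aromatic ring of carbon only. The read-out does not separate the exchange from the scatter in any of the three comparisons: a 1.2-fold higher number from compound 3 to compound 4 (0.09 log units; within the scatter), a 1.1-fold higher number from compound 2 to compound 4 (0.04 log units; within the scatter) and a 1.3-fold lower number from compound 1 to compound 4 (0.12 log units; within the scatter). Nothing available on these compounds offers an explanation for this result.

The compounds shown therefore leave open whether any group at this place can move the number beyond the scatter. As far as these compounds go, an amine, a carboxylic acid or a longer chain here could answer that, and the direction of any such step remains unknown.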